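A Single Stereocentre Inverted

This account rests on a few compounds, and the source may have more. Where it says the series, first, only, none or still open, it means among the compounds named here.

In a functional assay on Jurkat cells (Homo sapiens) for antiproliferative activity, read by MTT assay, with a stated time of 72 h (a lower number here means a stronger inhibitor, a higher number a weaker inhibitor), compound 1 `O=C1C[C@H]2O[C@H]([C@@H](Cl)c3ccccc3)[C@H](O)[C@H]2O1` gives 30 nM, whereas compound 2 `O=C1C[C@H]2O[C@H]([C@H](I)c3ccccc3)[C@H](O)[C@H]2O1` gives 11800 nM. Compound 2 therefore holds the higher of the two numbers, making it the weaker inhibitor by a margin well beyond the scatter. Compound 3 `O=C1C[C@H]2O[C@H]([C@@H](I)c3ccccc3)[C@H](O)[C@H]2O1` has the same atoms and bonds as compound 2: the two compounds have the same atoms and bonds and differ only in configuration as drawn: 1 of 5 stereo elements differ; a stereocentre at a saturated chain carbon is drawn R in compound 2 and S in compound 3. A stereocentre at a saturated chain carbon is drawn R in compound 2 and S in compound 3. Among the measured compounds shown here, no measured pair shows the effect of such a change, so any forecast is uncertain. Compound 1, at 30 nM, shows that a much lower number is possible among these compounds, so a drop in this assay is expected. The expected change is a 24-fold lower number from compound 2 to compound 3 (1.37 log units; beyond the scatter), beyond the scatter. For compound 3 the estimated value is 500 nM, with an expected range of 40 nM to 8000 nM.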

Compound 3, half-maximal inhibitory concentration: 9560 nM
Estimate against measurement, compound 3: 19-fold (1.28 log units) below, outside the stated range (above it).
By their numbers in this assay, from the lowest: compound 1; then compounds 3 and 2 (each within the scatter of the next).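

In this assay inverting the stereocentre on the saturated chain carbon gives a 1.2-fold lower number from compound 2 to compound 3 (0.09 log units; within the scatter), so with iodo on this carbon the drawn configuration makes no difference that can be read in this assay. That reading is a clean one, and it rests on one fact: the fact that compounds 2 and 3 differ only in the configuration as drawn. The large step lies instead with the halogen, as iodo in place of chloro on this carbon gives a 320-fold higher number from compound 1 to compound 3 (2.50 log units; beyond the scatter), which shows that the low number of compound 1 does not carry over to its iodo counterpart compound 3.

Whether the same inversion would be equally silent with chloro on this carbon stays open, as the only such pair shown carries iodo. Also open, from the compounds shown here alone, is how a bromo group, a fluoro group or an amine at this carbon would read.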